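The source may report more compounds than this note shows. Statements on the series, on what has been measured and on what is new or still open speak of the compounds shown alone.

Among the measured compounds shown here, compound 1, `CC1=C(C(=O)Nc2ccc(F)cc2)C(c2ccc([N+](=O)[O-])cc2)N=C(SCc2ccc(Cl)cc2)N1`, is one of three compounds measured in a functional assay on the whole organism (artery, strain albino) with Rattus norvegicus as the target, with a stated time of 900 min, at a dose of 10 mg/kg by the oral route (on this read-out higher numbers stand for more inhibition at the one dose given (going by the name of the read-out) and lower numbers for less inhibition), and in this assay compound 1 gives 16.9%. Compound 2, `CC1=C(C(=O)Nc2ccc(F)cc2)C(c2ccc([N+](=O)[O-])cc2)N=C(SCc2ccc(F)cc2)N1`, differs from compound 1 in one place: fluoro in place of chloro on an aromatic carbon. In this assay compound 2 gives 13.8%. The step recorded for this change is a number 3.1 percentage points lower from compound 1 to compound 2 (within the scatter). Compound 3, `CC1=C(C(=O)Nc2ccc(Br)cc2)C(c2ccc(Cl)cc2Cl)N=C(SCc2ccc(Cl)cc2)N1`, has a core that is not the core of compound 1; the difference between the two cores is not broken down here. In this assay compound 3 gives 22.1%, a number within the scatter of both compound 1 and compound 2.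

Compound 4, `CC1=C(C(=O)Nc2ccc(Br)cc2)C(c2ccc(Cl)cc2Cl)N=C(SCc2ccc(F)cc2)N1`, is not yet measured. It differs from compound 3 by fluoro in place of chloro on an aromatic carbon, the same change that carries compound 1 to compound 2, at the same kind of place. Its effect is expected to be of the same small size, because from compound 1 to compound 2 it produced a number 3.1 percentage points lower from compound 1 to compound 2 (within the scatter). For compound 4 in this assay the expected step is a number 3.1 percentage points lower from compound 3 to compound 4 (within the scatter). The value of compound 4 is therefore estimated at 19%, between 8% and 30%.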

Compound 4, a percentage reported as inhibition, in the whole organism at one dose (the size of the read-out at that dose, not a potency): 23.1%
Compound 4: the middle estimate sits 4.1 percentage points below what was measured; the range from low to high includes it.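

In this assay, the change from 4-chlorobenzyl to 4-fluorobenzyl on the core of compound 3 gives a number 1 percentage points higher from compound 3 to compound 4 (within the scatter). Set beside the same change on the core of compound 1, the step shows no detectable difference between the two cores: the same change on two cores in this assay, a number 3.1 percentage points lower (within the scatter) from compound 1 to compound 2 and a number 1 percentage points higher (within the scatter) from compound 3 to compound 4, 4.1 percentage points apart, within the scatter of two such steps This shows that, across these two pairs, the change stays small on both cores and that the step seen on one core held on the other, but it does not show that the change has no effect at all, fix the direction of any effect, or show that the step would hold on a further core.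

Only chloro and fluoro appear at this place on the benzyl group in the compounds shown, so it remains open what an amine, a carboxylic acid or a methoxy group there would do. On these data alone, a longer chain in place of the benzyl group, and the size of this step at another dose or time, also remain open.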